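Methylpyrazole in place of triazole on an aryl-imidazoline scaffold

This account rests on a few compounds, and the source may have more. Where it says the series, first, only, none or still open, it means among the compounds named here.

Compound 1 `c1ccc(-c2nc[nH]n2)c(NCC2=NCCN2)c1` carries a 1H-1,2,4-triazol-3-yl group and, in an in vitro functional assay on cells (Fibroblast) for agonist activity at Alpha-1A adrenergic receptor (Homo sapiens) (a higher number here means that more compound is needed for the effect, a lower number that less compound is needed), compound 1 gives 0.794 nM, the lowest of the two numbers available. Compound 2 `Cc1nc(-c2ccccc2NCC2=NCCN2)n(C)n1` stands nearest in this assay with 1000 nM, a gap well beyond the scatter. Compound 3 `CC(C)n1nccc1-c1ccccc1NCC1=NCCN1` is different: in this assay compound 3 gives only the limit < 100000 nM, so it is not a number, as noted in the limit of < 100000 nM in this assay, at which 1 of the 3 values shown sits.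

Compound 4 `Cn1ccc(-c2ccccc2NCC2=NCCN2)n1` is not yet measured. Relative to compound 1 the change is 1-methyl-1H-pyrazol-3-yl in place of 1H-1,2,4-triazol-3-yl on an aromatic carbon. The writer expects a step in this assay from compound 1 to compound 4 of a 130-fold higher number from compound 1 to compound 4 (2.10 log units; beyond the scatter) toward a higher number, since compound 2, which also lacks the donor, gives 1000 nM. Compound 4 is therefore expected to give about 100 nM, in a range from 10 nM to 1000 nM.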

Compound 4, half-maximal effective concentration: 3.16 nM
Compound 4: the middle estimate sits 32-fold (1.50 log units) above what was measured, and the stated range ends above it.
By their numbers in this assay, from the lowest: compound 1; then compound 4; then compound 2.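

In this assay, putting 1-methyl-1H-pyrazol-3-yl in place of 1H-1,2,4-triazol-3-yl gives a 4.0-fold higher number from compound 1 to compound 4 (0.60 log units; beyond the scatter), a step beyond the scatter but a modest one, so a five-membered aromatic ring with 0 hydrogen-bond donors can stand at this place on the aromatic carbon and compound 4 still gives 3.16 nM. This single step changes the donor count, the ring's hetero atoms and the heavy-atom count together, so it cannot show which of these changes accounts for the difference. Nothing measured here gives a cause for this step.

The effect of the added methyl alone remains open, as the compounds shown do not separate it from the change of ring. Also open, going by these compounds, is how an amine or a carboxylic acid at this place, or a longer chain in place of the methyl, would read in this assay.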